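Replacing a Hydroxymethyl-Bearing 1,2-Oxazole With a Bare Pyrazole

The source may hold more compounds than are shown below. What is called first, only, known or untested is meant among the compounds shown, and "the series" means these compounds.

Measured so far:
compound 1, `CCNC(=O)c1noc(-c2cc(C(C)C)c(O)cc2O)c1-c1cc(CO)no1`, 5 nM
compound 2, `CCNC(=O)c1noc(-c2cc(C(C)C)c(O)cc2O)c1-c1cc(CNC(C)=O)no1`, "not determined" (no result reported)
compound 3, `CCNC(=O)c1noc(-c2cc(C(C)C)c(O)cc2O)c1-c1cc(CN2CCCCC2)no1`, 62 nM

In a functional assay on A2780 cells (Homo sapiens) for inhibition (a lower number here means a stronger inhibitor, a higher number a weaker inhibitor), compound 1 gives 5 nM, the lowest of the two numbers reported. Its nearest neighbour is compound 3: a 12-fold higher number from compound 1 to compound 3 (1.09 log units; beyond the scatter). Compound 2 has no result in this assay.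

Compound 4 is `CCNC(=O)c1noc(-c2cc(C(C)C)c(O)cc2O)c1-c1cc[nH]n1`. It differs from compound 1 in one place: 1H-pyrazol-3-yl in place of 3-(hydroxymethyl)-1,2-oxazol-5-yl on an aromatic carbon. For the measured compounds named here, the only measured step, from compound 1 to compound 3, touched just the hydroxy on the saturated chain carbon and was large; it does not cover exchanging the whole ring. A moderate loss is therefore expected, a 4.0-fold higher number from compound 1 to compound 4 (0.60 log units; beyond the scatter), giving compound 4 an estimated 20 nM in this assay, with a range from 5 nM to 100 nM.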

Compound 4, half-maximal inhibitory concentration: 33 nM
Beside the measured number, compound 4's estimate is 1.7-fold (0.22 log units) below it; the range from low to high includes it.
By their numbers in this assay, from the lowest: compound 1; then compounds 4 and 3 (each within the scatter of the next).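

In this assay, exchanging the whole 3-(hydroxymethyl)-1,2-oxazol-5-yl for the smaller 1H-pyrazol-3-yl gives a 6.6-fold higher number from compound 1 to compound 4 (0.82 log units; beyond the scatter), a real but modest loss. The earlier compounds shown here changed only the end of the side chain, whereas this result shows that the ring and its hydroxymethyl can go together and nanomolar activity remains. No measurement shown explains the loss. Still open, from the compounds shown here alone, is whether the loss follows the ring exchange or the missing hydroxymethyl, which a 1H-pyrazol-3-yl carrying hydroxymethyl could separate. Going by these compounds, how an amine or a carboxylic acid on the pyrazole would fare also remains open.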